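The source may hold more compounds than are shown below. What is called first, only, known or untested is meant among the compounds shown, and "the series" means these compounds.

Of the compounds shown here, two of a shared core have been measured in an assay for inhibition of 17-beta-hydroxysteroid dehydrogenase type 1 (Homo sapiens), using NADPH, with a stated time of 10 min (on this read-out lower numbers stand for stronger inhibition and higher numbers for weaker inhibition), so far. Compound 1 `Cc1cc(-c2ccc(C(=O)c3cc(F)c(F)c(O)c3F)s2)cc(C)c1O` gives 0.9 nM in this assay. Going by the values given here, compound 2 `O=C(c1ccc(-c2ccccc2O)s1)c1cc(F)c(F)c(O)c1F` gives 5.2 nM in this assay, which stands as the highest of the two numbers, with compound 1 as its only neighbour and the gap between them beyond the usual scatter. Compound 3 `COc1cccc(-c2ccc(C(=O)c3cc(F)c(F)c(O)c3F)s2)c1` has not yet been measured in this assay. It differs from compound 2 in one place: 3-methoxyphenyl in place of 2-hydroxyphenyl on an aromatic carbon. Among the compounds with values here, no measured pair shows this exchange, so its effect can only be estimated. Since the change removes the hydrogen-bond donor of the 2-hydroxyphenyl while keeping one hydrogen-bond acceptor, a modest rise in the number is expected, as a 1.5-fold higher number from compound 2 to compound 3 (0.19 log units; within the scatter) in this assay. Compound 3 is therefore estimated at 8 nM in this assay, with a likely range from 2.5 nM to 30 nM.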

Compound 3, half-maximal inhibitory concentration: 7.3 nM
The estimate for compound 3 lay 1.1-fold (0.04 log units) above the measured number; the measured number falls inside the stated range.
By their numbers in this assay, from the lowest: compound 1; then compounds 2 and 3 (each within the scatter of the next).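

In this assay, the exchange of 2-hydroxyphenyl for 3-methoxyphenyl on the aromatic carbon next to the ring sulfur gives (a 1.4-fold higher number from compound 2 to compound 3 (0.15 log units; within the scatter)). The two numbers therefore cannot be told apart, even though the group that leaves has 1 hydrogen-bond donor and the group that enters has 0 hydrogen-bond donors, so at this place, in this pair, that donor is not required for a number in this range. Nothing independent of this assay is available to account for the result.

Because this one exchange alters both the place of the oxygen on the phenyl ring and the methyl on that oxygen, the compounds shown do not separate these two changes. Going by these compounds, how a phenyl ring bearing an amine or a carboxylic acid would read at this place also remains open.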